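The source may report more compounds than this note shows. Statements on the series, on what has been measured and on what is new or still open speak of the compounds shown alone.

Three compounds sharing one core have been measured in a functional assay on the whole organism (strain albino CF-1) with Mus musculus as the target, in the maximal electroshock model, with a stated time of 4 h; a lower number here means that less compound is needed, a higher number that more compound is needed for the effect:

Compound 1, `C=CCCOc1cccc(/C=N/n2c(-c3ccccc3)nc3ccccc3c2=O)c1`, gives 100 mg/kg.
Compound 2, `CCOc1cccc(/C=N/n2c(-c3ccccc3)nc3ccccc3c2=O)c1`, gives 100 mg/kg.
Compound 3, `CCCCOc1cccc(/C=N/n2c(-c3ccccc3)nc3ccccc3c2=O)c1`, gives 100 mg/kg.

Compound 3 thus stands level with compounds 1 and 2 at the digits shown. Every step among the three is within the scatter: no change at the digits printed from compound 1 to compound 2 (within the scatter), no change at the digits printed from compound 1 to compound 3 (within the scatter) and no change at the digits printed from compound 2 to compound 3 (within the scatter). These steps exchange hydrogen, vinyl and ethyl on a saturated chain carbon, two bonds along the chain from an oxygen on an aromatic ring, and none of them moved the number.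

Compound 4, `CC(C)Oc1cccc(/C=N/n2c(-c3ccccc3)nc3ccccc3c2=O)c1`, has not yet been measured. It differs from compound 3 by isopropyl in place of butyl on an oxygen on an aromatic ring. This change belongs to the same family as the measured steps, a change in the chain attached to the oxygen on an aromatic ring, and those steps were all within the scatter. Within the data shown here, no measured step covers a branched chain directly, so the expectation is a step no larger than the scatter. Compound 4 is therefore expected to give 100 mg/kg, within 50 mg/kg to 200 mg/kg. That estimate means an expected step of no change at the digits printed from compound 3 to compound 4 (within the scatter).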

Compound 4, minimum effective dose: 300 mg/kg
Compound 4: the middle estimate sits 3.0-fold (0.48 log units) below what was measured, outside the stated range (above it).
By their numbers in this assay, from the lowest: compounds 1, 2 and 3 (each within the scatter of the next); then compound 4.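

In this assay, the unbranched chains on the oxygen on an aromatic ring left the number unchanged, yet isopropyl in place of butyl gives a 3.0-fold higher number from compound 3 to compound 4 (0.48 log units; beyond the scatter) and so shows that this position does respond to the kind of chain it carries. The other two comparisons agree: methyl in place of hydrogen on the chain carbon bound to the oxygen gives a 3.0-fold higher number from compound 2 to compound 4 (0.48 log units; beyond the scatter) and isopropyl in place of but-3-en-1-yl gives a 3.0-fold higher number from compound 1 to compound 4 (0.48 log units; beyond the scatter) with no exception among these four compounds, since only compound 4 carries a branch and only compound 4 needs more compound. No measured information on these compounds explains this difference.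

With a single branched chain shown, it remains open whether a branch further out, as in isobutyl, would behave like isopropyl. Going by these compounds, a ring on the same oxygen, such as cyclopentyl, or a longer chain such as hexyl, also remains untested here.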